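Bridged bicyclic amine replacing cyclopentyl(methyl)amino on the shared core

The source may hold more compounds than are shown below. What is called first, only, known or untested is meant among the compounds shown, and "the series" means these compounds.

Measured compounds:
compound 1 `CN(c1ccc2cc(NC(=O)CCc3ccc(C(F)(F)F)cc3)ccc2n1)C1CCCCC1` — 18 nM
compound 2 `CN(c1ccc2cc(NC(=O)CCc3ccc(C(F)(F)F)cc3)ccc2n1)C1CCCC1` — 2 nM
compound 3 `O=C(CCc1ccc(C(F)(F)F)cc1)Nc1ccc2nc(N3CCCC3)ccc2c1` — 3 nM; 3 nM (2 entries)

All three compounds share the same core and differ only in the amine attached to it. In an assay on isolated protein for displacement of a labelled ligand from melanin-concentrating hormone receptor 1 (Homo sapiens) (a lower number here means a stronger inhibitor, a higher number a weaker inhibitor), compound 2 gives 2 nM and stands at the lower end of the numbers here: its nearest measured neighbour with a single number is compound 1, and the step of a 9.0-fold lower number from compound 1 to compound 2 (0.95 log units; beyond the scatter) shows that the smaller ring gave a clearly stronger result. Compound 3 gives 3 nM; 3 nM (2 entries) in this assay, which lies within the scatter of compound 2, so the two cannot be ordered.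

Compound 4 `O=C(CCc1ccc(C(F)(F)F)cc1)Nc1ccc2nc(N3CC4CC3CO4)ccc2c1` has not yet been measured. Its change from compound 2 is a group of 7 heavy atoms (5 carbon, 1 nitrogen, 1 oxygen; 2 five-membered non-aromatic rings with 1 hetero atom each) in place of a group of 7 heavy atoms (6 carbon, 1 nitrogen; one five-membered non-aromatic ring of carbon only), on an aromatic carbon. Going by the values given here, the only step on record, the one from compound 1 to compound 2, concerns the size of a carbon ring and says little about introducing 2 five-membered non-aromatic rings with 1 hetero atom each. The values of compound 2 and compound 3 suggest that different amines in this place are tolerated. Compound 4 is therefore expected to stay in the strong range, with a modest step of a 3.0-fold higher number from compound 2 to compound 4 (0.48 log units; beyond the scatter) toward a somewhat higher number. The estimate for compound 4 in this assay is 6 nM, with a range from 1.5 nM to 25 nM.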

Compound 4, half-maximal inhibitory concentration: 13 nM
For compound 4 the middle estimate is 2.2-fold (0.34 log units) below the measured one; the range from low to high includes it.
By their numbers in this assay, from the lowest: compound 2; then compounds 4 and 1 (each within the scatter of the next).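

In this assay, swapping cyclopentyl(methyl)amino for the bridged bicyclic amine on this aromatic carbon, next to the ring nitrogen, gives a 6.5-fold higher number from compound 2 to compound 4 (0.81 log units; beyond the scatter), even though the entering and leaving groups have the same heavy-atom count. Matching that count is therefore not enough to keep the number low here, and the tolerance suggested by the earlier amines has a limit. Compared with the cyclohexyl compound, the result is a 1.4-fold lower number from compound 1 to compound 4 (0.14 log units; within the scatter), so two quite different amines cannot be ordered in this assay, and no measurement shown here explains why the bridged amine gives a higher number than cyclopentyl(methyl)amino.

The compounds shown leave open whether the ring oxygen or the bridged ring framework accounts for the step from compound 2, a question that an all-carbon bridged amine of the same shape and a simple morpholine could help to separate. On these data alone, it is also open whether the same amine change would give a similar step if the trifluoromethyl group on the other end of the molecule were replaced by a chlorine atom.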